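Swapping methylsulfanyl for methyl at the assay limit

A few compounds are considered here, and "the series" means these few. Any claim that something is new, unique, unknown or untested is made for them only; others in the source may bear on it.

Compound 1 (`CSc1ncnc2c1c(-c1ccoc1)cn2[C@@H]1O[C@H](CO)[C@@H](O)[C@H]1O`) was tested in an ADME assay on MRC5 cells (Homo sapiens), read by MTT assay, with a stated time of 72 h; on this read-out lower numbers stand for stronger inhibition and higher numbers for weaker inhibition. Compound 1 gives > 100000 nM, which is a limit and not a number. Compound 2 (`CSc1ncnc2c1c(-c1ccsc1)cn2[C@@H]1O[C@H](CO)[C@@H](O)[C@H]1O`) carries thiophen-3-yl in place of furan-3-yl, and compound 2 gives > 100000 nM, also a limit. Compound 3 (`C#Cc1cn([C@@H]2O[C@H](CO)[C@@H](O)[C@H]2O)c2ncnc(SC)c12`) carries ethynyl instead, and compound 3 gives > 100000 nM, again a limit. The whole picture is therefore (the limit of > 100000 nM in this assay, at which 3 of the 3 values shown sit).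

Compound 4 (`Cc1ncnc2c1c(-c1ccoc1)cn2[C@@H]1O[C@H](CO)[C@@H](O)[C@H]1O`) differs from compound 1 in a single place: methyl in place of methylsulfanyl on an aromatic carbon. Methyl takes the place of methylsulfanyl on an aromatic carbon.

The measured steps bear on this only indirectly, since none of them touches the methylsulfanyl. They are a step that the two limits leave unreadable from compound 1 to compound 2, a step that the two limits leave unreadable from compound 1 to compound 3 and a step that the two limits leave unreadable from compound 2 to compound 3. None has a readable size, so they offer no measured guide to the new swap. The expectation is that compound 4 stays close to the same limit in this assay, and a limit may well be reported again. If a number does appear, it can only point towards stronger inhibition, and the expected step is an at least 1.4-fold lower number from compound 1 to compound 4 (0.15 log units; that floor lies within the scatter). For compound 4 the estimate is 70000 nM, with an expected range of 10000 nM to 100000 nM.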

Compound 4, half-maximal inhibitory concentration: 98300 nM
Compound 4: middle estimate off by 1.4-fold (0.15 log units), on the low side, within the range that was stated.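

With methyl in place of methylsulfanyl on the aromatic carbon next to the ring nitrogen, compound 4 gives the first true number among these compounds in this assay, at 98300 nM. The swap reads as an at least 1.0-fold lower number from compound 1 to compound 4 (0.00 log units; that floor lies within the scatter), so only a floor can be put on its size, and that floor does not separate the two compounds. The steps among compound 1, compound 2 and compound 3 cannot be read, which makes this the only step with any readable size, yet compound 4 still stands very close to where the others stop being measurable, and the series as a whole remains defined by: the limit of > 100000 nM in this assay, at which 3 of the 4 values shown sit.

Whether methyl would also bring a true number with thiophen-3-yl or ethynyl in place of furan-3-yl stays open, as the methyl swap is shown here only on the furan-3-yl compound. Going by these compounds, how an amine, a methoxy group or a longer chain such as propyl on this same aromatic carbon would read in this assay also stays open, including whether any of them would give a number well clear of the limit.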